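This account rests on a few compounds, and the source may have more. Where it says the series, first, only, none or still open, it means among the compounds named here.

Measured compounds in the series:
compound 1, `c1ccc([C@H]2CCC[C@@H](CCN3CCCC3)C2)cc1`: 3.6 nM
compound 2, `NCC[C@@H]1CCC[C@H](c2ccccc2)C1`: 167 nM
compound 3, `CN(C)CC[C@@H]1CCC[C@H](c2ccccc2)C1`: 14 nM

In an assay on membranes from brain for displacement of a labelled ligand from Sigma non-opioid intracellular receptor 1 (Cavia porcellus), read by scintillation counting, with a stated time of 120 min (on this read-out lower numbers stand for stronger inhibition and higher numbers for weaker inhibition), compound 1 gives the lowest number of the three. The steps recorded so far all change the amine on the chain: a 46-fold higher number from compound 1 to compound 2 (1.67 log units; beyond the scatter), a 3.9-fold higher number from compound 1 to compound 3 (0.59 log units; beyond the scatter) and a 12-fold lower number from compound 2 to compound 3 (1.08 log units; beyond the scatter).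

Compound 4, `c1ccc([C@@H]2CCC[C@@H](CCN3CCCC3)C2)cc1`, differs from compound 1 only in configuration: the two compounds have the same atoms and bonds and differ only in configuration as drawn: 1 of 2 stereo elements differ; a stereocentre at a saturated ring carbon is drawn S in compound 1 and R in compound 4. Going by the values given here, none of the measured steps touches a stereocentre, so nothing here bears directly on this change; a step in either direction or none beyond the scatter is possible, and the range must stay wide. Compound 4 is estimated at 10 nM (range 2 nM to 60 nM), which as a step from compound 1 means an expected 2.8-fold higher number from compound 1 to compound 4 (0.44 log units; beyond the scatter).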

Compound 4, inhibition constant: 2 nM
Estimate against measurement, compound 4: 5.0-fold (0.70 log units) above, within the range that was stated.
By their numbers in this assay, from the lowest: compounds 4 and 1 (each within the scatter of the next); then compound 3; then compound 2.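

The change of the stereocentre at a saturated ring carbon from S to R gives a 1.8-fold lower number from compound 1 to compound 4 (0.26 log units; within the scatter) in this assay and so, with the pyrrolidin-1-yl chain in place, configuration at this position has no effect beyond the scatter. The earlier steps shown here, all at the amine, showed nothing about this centre. Any reading of this pair rests on one structural change:  the fact that compounds 1 and 4 differ only in the configuration as drawn

Open, going by these compounds, is whether this holds with the amino chain of compound 2 or the dimethylamino chain of compound 3. Also open, on these data alone, are the other stereocentre and a piperidine or longer chain.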